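This account rests on a few compounds, and the source may have more. Where it says the series, first, only, none or still open, it means among the compounds named here.

In a functional assay on SKBR cells (Homo sapiens) for cytotoxicity, read by resazurin assay, with a stated time of 72 h; a lower number here means a stronger inhibitor, a higher number a weaker inhibitor:

compound 1 `O=C(/C=C/c1ccc(OCCCCCO[N+](=O)[O-])c(O)c1)OCCCCCO[N+](=O)[O-]` gives 2710 nM.
compound 2 `COc1cc(/C=C/C(=O)OCCCO[N+](=O)[O-])ccc1OCCCO[N+](=O)[O-]` reaches only the limit > 50000 nM.
compound 3 `COc1cc(/C=C/C(=O)OCCCCCO[N+](=O)[O-])ccc1OCCCCCO[N+](=O)[O-]` also reaches only the limit > 50000 nM.

Compound 4 `O=C(/C=C/c1ccc(OCCCO[N+](=O)[O-])c(O)c1)OCCCO[N+](=O)[O-]` has not been measured. Going by the values given here, compound 1 differs from compound 3 by hydrogen in place of methyl on an oxygen on an aromatic ring, and the step of an at least 18-fold lower number from compound 3 to compound 1 (1.26 log units; beyond the scatter) is the only measured instance of that change. Compound 4 differs from compound 2 in the same way, (hydrogen in place of methyl on an oxygen on an aromatic ring), at the same place. The difference between the cores of compound 2 and compound 3 is not broken down here; both of their values sit at the limit of > 50000 nM in this assay, at which 2 of the 3 values shown sit, so it is not known whether the two cores behave alike. A step of similar size is nonetheless expected, an at least 12-fold lower number from compound 2 to compound 4 (1.09 log units; beyond the scatter), resting on an at least 18-fold lower number from compound 3 to compound 1 (1.26 log units; beyond the scatter). Compound 4 is therefore estimated at 4000 nM, between 1200 nM and 20000 nM.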

Compound 4, half-maximal inhibitory concentration: 4810 nM
For compound 4 the middle estimate is 1.2-fold (0.08 log units) below the measured one, within the range that was stated.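

In this assay the change from methoxy to hydroxy again gives a large drop in the number on the second core, an at least 10-fold lower number from compound 2 to compound 4 (1.01 log units; beyond the scatter) and so it carries over in direction and beyond the scatter. The two steps can be set side by side only with caution: the same change on two cores in this assay, an at least 18-fold lower number (1.26 log units; beyond the scatter) from compound 3 to compound 1 and an at least 10-fold lower number (1.01 log units; beyond the scatter) from compound 2 to compound 4; the limit leaves it open whether they differ. The series therefore shows that the change lowers the number on both cores, but it gives neither the true size of either step nor any sign that the two sizes match.

Any difference between the cores of compound 2 and compound 3 cannot be read: the limit of > 50000 nM in this assay, at which 2 of the 4 values shown sit. On these data alone, it also remains open how the step would behave with a longer chain, or with an amine in place of the hydroxy.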